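A few compounds are considered here, and "the series" means these few. Any claim that something is new, unique, unknown or untested is made for them only; others in the source may bear on it.

Measured compounds:
compound 1 `Cc1noc2c1N=C(c1ccco1)CC(c1ccccc1)C2C(c1ccccc1)C1c2onc(C)c2N=C(c2ccco2)CC1c1ccccc1`, 32.7 ug/mL
compound 2 `Cc1noc2c1N=C(c1cccs1)CC(c1ccccc1)C2C(c1ccccc1)C1c2onc(C)c2N=C(c2cccs2)CC1c1ccccc1`, 28.5 ug/mL
compound 3 `Cc1ccc(C(C2c3onc(C)c3N=C(c3ccccc3)CC2c2ccccc2)C2c3onc(C)c3N=C(c3ccccc3)CC2c2ccccc2)cc1`, 38.4 ug/mL

All three were tested in a functional assay on HeLa cells (Homo sapiens) for cytotoxicity, read by MTT assay, with a stated time of 48 h; a higher number here means a weaker inhibitor, a lower number a stronger inhibitor. In this assay compound 1 gives 32.7 ug/mL, compound 2 gives 28.5 ug/mL and compound 3 gives 38.4 ug/mL. Compound 3 carries the largest of the three numbers, but its gap to compound 1 and its gap to compound 2 both lie within the scatter of repeat measurements, so none of the three can be set apart from another in this assay.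

Compound 4 `Cc1noc2c1N=C(c1ccccc1)CC(c1ccccc1)C2C(c1ccc(Cl)cc1)C1c2onc(C)c2N=C(c2ccccc2)CC1c1ccccc1` has not yet been measured. It differs from compound 3 in one place: chloro in place of methyl on an aromatic carbon. The rest of the molecule is untouched. Going by the values given here, no pair of measured compounds shows the effect of this particular exchange, and the three measured compounds, which differ among themselves in other ways, all sit within the scatter of one another. On that basis the step of a 1.1-fold lower number from compound 3 to compound 4 (0.04 log units; within the scatter) is expected to be small, in neither direction beyond the scatter. Compound 4 is therefore estimated at 35 ug/mL in this assay, with an expected range from 20 ug/mL to 62 ug/mL.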

Compound 4, half-maximal inhibitory concentration: 55.9 ug/mL
The estimate for compound 4 lay 1.6-fold (0.20 log units) below the measured number; measured number inside the range.
By their numbers in this assay, from the lowest: compounds 2, 1, 3 and 4 (each within the scatter of the next).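

The pair of compound 3 and compound 4 is the first among the compounds shown that differ in one place, so chloro in place of methyl, on an aromatic carbon para to a large group, can now be read on its own. In this assay this exchange amounts to a 1.5-fold higher number from compound 3 to compound 4 (0.16 log units; within the scatter), so 4-chlorophenyl and 4-methylphenyl cannot be told apart at this position in this cell read-out. Nothing measured here bears on why the step has this size.

The compounds shown leave open how other groups at this same position would read, such as a methoxy group, an amine or a carboxylic acid, as methyl and chloro are the only two substituents seen there and a single pair says nothing about a wider trend. They also leave open whether the same exchange would read alike on the background of compound 1 or compound 2, where the groups elsewhere on the shared core differ from those of compound 3.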